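Replacing the Hydroxyphenyl Group in a Piperazine Series

The source may hold more compounds than are shown below. What is called first, only, known or untested is meant among the compounds shown, and "the series" means these compounds.

Compound 1 `CN(C)c1ccccc1N1CCN(CCCCn2ncc(=O)n(C)c2=O)CC1`: 350 nM
Compound 2 `Cn1c(=O)cnn(CCCCN2CCN(c3c(Br)cccc3C#N)CC2)c1=O`: 450 nM
Compound 3 `Cn1c(=O)cnn(CCCCN2CCN(c3cccc(O)c3)CC2)c1=O`: > 10000 nM

In an assay for displacement of a labelled ligand from Adrenergic receptor alpha-1 (Homo sapiens) (on this read-out higher numbers stand for weaker inhibition and lower numbers for stronger inhibition), compound 1 gives 350 nM and compound 2 gives 450 nM; the step of a 1.3-fold higher number from compound 1 to compound 2 (0.11 log units; within the scatter) is small. For compound 3 only a limit is known, (the limit of > 10000 nM in this assay, at which 1 of the 3 values shown sits), so its place on the numbers shown is at the weak edge. The steps of an at least 28-fold higher number from compound 1 to compound 3 (1.45 log units; beyond the scatter) and an at least 22-fold higher number from compound 2 to compound 3 (1.34 log units; beyond the scatter) are both large, and both have the 3-hydroxyphenyl group entering on the ring nitrogen.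

Compound 4 `Cn1c(=O)cnn(CCCCN2CCN(c3ncccc3F)CC2)c1=O` has not been measured. Its change from compound 3 is 3-fluoropyridin-2-yl in place of 3-hydroxyphenyl on an amine nitrogen in a ring. The hydroxyphenyl group, which accompanied the two large weakenings, leaves, and a group without a hydrogen-bond donor takes its place, as in compounds 1 and 2. The step from compound 3 to compound 4 is therefore expected to be a decrease in the number, an at least 14-fold lower number from compound 3 to compound 4 (1.15 log units; beyond the scatter). Compound 4 is estimated at 700 nM, within 150 nM to 4000 nM.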

Compound 4, inhibition constant: > 10000 nM
Compound 4: no number, only a limit (the forecaster's own chance of this, stated with the estimate: 10%); at least 14-fold (1.15 log units) between middle value and limit.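

Moving from the 3-hydroxyphenyl group to a group with no hydrogen-bond donor on the ring amine nitrogen does not by itself bring back the binding seen in compound 1 and compound 2. With 3-fluoropyridin-2-yl at this position, the loss remains large on both comparisons (an at least 22-fold higher number from compound 2 to compound 4 (1.34 log units; beyond the scatter)) and (an at least 28-fold higher number from compound 1 to compound 4 (1.45 log units; beyond the scatter)). The value of compound 4 is a limit and not a number, and the step from the other limit compound cannot be read: the limit of > 10000 nM in this assay, at which 2 of the 4 values shown sit.

The compounds shown leave open whether the ring nitrogen or the fluorine of the 3-fluoropyridin-2-yl group goes with the loss. A plain pyridin-2-yl or a 2-methoxyphenyl group on the same nitrogen would help to separate the two.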